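This account rests on a few compounds, and the source may have more. Where it says the series, first, only, none or still open, it means among the compounds named here.

Among the measured compounds shown here, compound 3 `COc1ccc(CNC(=O)/C(C#N)=C/c2ccc(C)o2)cc1` sits at the low end of the numbers so far: in a functional assay on BE(2)-C cells (Homo sapiens) for inhibition, read by MTT assay, with a stated time of 72 h (a higher number here means a weaker inhibitor of growth, a lower number a stronger inhibitor of growth), compound 3 gives 21000 nM. For the measured compounds named here, compound 1 `COc1ccc(CNC(=O)/C(C#N)=C/c2ccc[nH]2)cc1` gives 47000 nM, and the step of a 2.2-fold lower number from compound 1 to compound 3 (0.35 log units; beyond the scatter) is the only single-change comparison available. Compound 2 `N#C/C(=C\c1ccco1)C(=O)NCc1ccc(Cl)c(Cl)c1` is reported only as a limit, > 50000 nM, which is the limit of > 50000 nM in this assay, at which 1 of the 3 values shown sits. Compound 4 `COc1ccc(CNC(=O)/C(C#N)=C/c2ccc(-c3ccccc3)o2)cc1` differs from compound 3 by phenyl in place of methyl on an aromatic carbon. Going by the values given here, no measured step covers this change; the one measured step in the set was modest, so a step of similar size, or none beyond the scatter, is expected here. Compound 4 is expected to give 15000 nM, with a range from 5000 nM to 50000 nM. The expected step is a 1.4-fold lower number from compound 3 to compound 4 (0.15 log units; within the scatter).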

Compound 4, concentration for 50% growth inhibition: > 100000 nM
Compound 4 ended at the assay's limit; the forecaster's own chance of this, stated with the estimate: 25%; middle value at least 6.6-fold (0.82 log units) away from the limit.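

In this assay, the position next to the ring oxygen does not accept every group: phenyl in place of methyl gives an at least 4.7-fold higher number from compound 3 to compound 4 (0.67 log units; beyond the scatter) and removes the modest gain seen with compound 3. On these data alone, the true size of this step remains unknown, as compound 4 is reported only as a limit: the limit of > 100000 nM in this assay, at which 1 of the 4 values shown sits.

As far as these compounds go, it remains open whether an ethyl or a longer alkyl chain at this position retains the growth inhibition of compound 3. From the compounds shown here alone, it is also open whether a phenyl bearing an amine or a carboxylic acid gives a value within the assay's range.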